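Methoxy to hydroxy on compound 2: growth-inhibition notes

This account rests on a few compounds, and the source may have more. Where it says the series, first, only, none or still open, it means among the compounds named here.

Measured in a functional assay on K562 cells (Homo sapiens) for inhibition, read by sulforhodamine B assay, with a stated time of 48 h; a lower number here means a stronger inhibitor of growth, a higher number a weaker inhibitor of growth:
- compound 1 `COc1ccc(/C=C/C2(C)C=CC(=O)O2)c(OC)c1`: > 1000000 nM (a limit)
- compound 2 `COc1ccc(/C=C/C2(C)C=CC(=O)O2)c(OC)c1OC`: > 1000000 nM (a limit)

Compound 2 stands at > 1000000 nM, which is a limit of the assay and not a number. Going by the values given here, the series so far shows only (the limit of > 1000000 nM in this assay, at which 2 of the 2 values shown sit). Compound 3 `COc1c(O)ccc(/C=C/C2(C)C=CC(=O)O2)c1OC` carries hydrogen in place of methyl on an oxygen on an aromatic ring, that is, methoxy to hydroxy. Among the compounds with values here, the one measured step that bears on this is a step that the two limits leave unreadable from compound 1 to compound 2, which also concerns a methoxy group on an aromatic carbon. It gives no size and no direction to carry over, so any step in this assay is expected only weakly, and another limit is the likeliest result. For compound 3 the estimate is 700000 nM, with an expected range from 200000 nM to 1000000 nM. The estimate implies an at least 1.4-fold lower number from compound 2 to compound 3 (0.15 log units; that floor lies within the scatter).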

Compound 3, concentration for total growth inhibition: > 1000000 nM
Compound 3: a limit, no number; the forecaster's own chance of this, stated with the estimate: 70%; at least 1.4-fold (0.15 log units) between middle value and limit.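

No new step can be read: compound 2 and compound 3 both sit at a limit of the assay and not at a number, so the step between them has neither size nor direction: the limit of > 1000000 nM in this assay, at which 3 of the 3 values shown sit.

The compounds shown leave open whether methoxy to hydroxy alters growth inhibition at all, and which change to the shared core would give a measurable value.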